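The source may report more compounds than this note shows. Statements on the series, on what has been measured and on what is new or still open speak of the compounds shown alone.

Measured compounds:
- compound 1, `C=CCn1c(=O)/c(=C\c2cccc(Cl)c2)[nH]c(=O)/c1=C\c1ccccc1OC`: 1200 nM
- compound 2, `C=CCn1c(=O)/c(=C\c2ccc(Cl)c(Cl)c2)[nH]c(=O)/c1=C\c1ccccc1OC`: "not active" (no number reported)
- compound 3, `C=CCn1c(=O)/c(=C\c2ccc(F)c(Br)c2)[nH]c(=O)/c1=C\c1ccccc1OC`: "not active" (no number reported)

Going by the values given here, in a functional assay on U-937 cells (Homo sapiens) for cytotoxicity, read by CCK-8 assay, with a stated time of 72 h (a higher number here means a weaker inhibitor, a lower number a stronger inhibitor), compound 1 gives 1200 nM and is the only member of the series with a numerical result. Among the compounds with values here, compound 2 and compound 3, which carry two halogens on the same ring, were reported as not active without a number, so no step within the measured set can be quantified, and nothing can be said about the size of the move from a single chloro substituent to two halogens beyond the bare fact that the single-chloro compound is the one that returned a value.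

Compound 4, `C=CCn1c(=O)/c(=C\c2cccc(C)c2)[nH]c(=O)/c1=C\c1ccccc1OC`, is the next entry to be measured in this assay. Relative to compound 1 the change is methyl in place of chloro on an aromatic carbon. Within the data shown here, no measured pair shows this exchange, so the expected step rests on the change alone: methyl replacing chloro, same heavy-atom count, no change in donors, acceptors or charge. The step from compound 1 to compound 4 is expected to be a 1.3-fold higher number from compound 1 to compound 4 (0.10 log units; within the scatter), which is within the usual scatter, with no clear direction. Compound 4 is therefore expected to give about 1500 nM, in the range 500 nM to 5000 nM.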

Compound 4, half-maximal inhibitory concentration: 5100 nM
Estimate against measurement, compound 4: 3.4-fold (0.53 log units) below; measured number above the stated range.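

In this assay, going by these compounds alone, the exchange of 3-chlorophenyl for 3-methylphenyl yields the only readable step, a 4.3-fold higher number from compound 1 to compound 4 (0.63 log units; beyond the scatter), so this is the first quantified change at any position. The place on the aromatic carbon, meta to a large group, is therefore sensitive to a swap of one heavy atom for one heavy atom, even with no change in hydrogen-bond donors, hydrogen-bond acceptors or net charge, and a numerical result is retained with either chloro or methyl there. No measured property of either group bears on this step, so the data give no explanation for it.

The compounds shown leave open how a fluoro, methoxy, amino or carboxylic acid group at this same place would read against chloro and methyl, and whether the step seen here would hold in the presence of a second substituent on that ring. Compound 2 and compound 3 carry no number, so any steps involving them cannot be read, and the effect of adding a second halogen remains unquantified.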